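Compound 3 to compound 4: a changed pyridinyl group

The compounds below may be only part of what the source reports. "The series", "measured", "known", "first", "only" and "open" are said of these compounds alone.

- Compound 1 `Cn1c(COc2cccc(C(=O)O)c2)nc2ccc(Oc3ccc(F)cc3)nc21`: 11 ug/mL
- Compound 2 `Cc1cc(C)cc(Oc2ccc3nc(COc4cccc(C(=O)O)c4)n(C)c3n2)c1`: 0.5 ug/mL
- Compound 3 `Cn1c(COc2cccc(C(=O)O)c2)nc2ccc(Oc3ccc(Cl)cn3)cc21`: 17 ug/mL

These numbers come from a physicochemical assay for solubility, read by HPLC, measured as thermodynamic solubility, with a stated time of 4 h, at pH 6.8; a lower number here means a less soluble compound, a higher number a more soluble compound. Compound 3 at 17 ug/mL cannot be told apart from compound 1 at 11 ug/mL, since the two lie within the usual scatter. Compound 2 at 0.5 ug/mL sits far lower than both, well beyond that scatter.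

Compound 4 `Cn1c(COc2cccc(C(=O)O)c2)nc2ccc(Oc3ncccc3F)cc21` has not been measured. Its difference from compound 3 is 3-fluoropyridin-2-yl in place of 5-chloropyridin-2-yl on an oxygen on an aromatic ring. Both groups are one six-membered aromatic ring with 1 hetero atom, and both carry no net charge.

Among the measured compounds shown here, only one measured step bears on this place: a 22-fold lower number from compound 1 to compound 2 (1.34 log units; beyond the scatter). It was large, so the group on this oxygen can matter. However, that step replaced a 4-fluorophenyl with a 3,5-dimethylphenyl, a different kind of change, and no measured step shows a swap between pyridinyl groups. No shift beyond the scatter is therefore expected in this assay.

The estimated step is a 1.3-fold higher number from compound 3 to compound 4 (0.11 log units; within the scatter), which would stay within the scatter. For compound 4 the expected value is 22 ug/mL, with an estimated range from 7 ug/mL to 65 ug/mL when measured.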

Compound 4, solubility: 7.1 ug/mL
The estimate for compound 4 lay 3.1-fold (0.49 log units) above the measured number; low and high end bracket the measured number.
By their numbers in this assay, from the lowest: compound 2; then compounds 4, 1 and 3 (each within the scatter of the next, the first and the last beyond it).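

In this assay, 3-fluoropyridin-2-yl in place of 5-chloropyridin-2-yl gives a 2.4-fold lower number from compound 3 to compound 4 (0.38 log units; beyond the scatter), a modest step but one beyond the usual scatter. This shows that the number can move at this place, on an oxygen on an aromatic ring, even when one pyridinyl group replaces another with the same count of heavy atoms, hydrogen-bond donors and acceptors and no net charge; the earlier step at this place involved only phenyl groups. Nothing available here speaks to what lies behind this step.

The two group names differ both in the halogen and in the number that gives its place, and the compounds shown do not separate those two differences. Going by these compounds, how a pyridinyl group carrying an amine or a methoxy group would read here also remains open.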